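A few compounds are considered here, and "the series" means these few. Any claim that something is new, unique, unknown or untested is made for them only; others in the source may bear on it.

Of the compounds shown here, three built on one shared core have been measured in a functional assay on SMMC-7721 cells (Homo sapiens) for antiproliferative activity, read by MTT assay, with a stated time of 72 h; on this read-out higher numbers stand for weaker inhibition and lower numbers for stronger inhibition. Compound 1 `CN(C(=O)CCc1ccccc1)c1ccc2[nH]c(-c3n[nH]c4ccccc34)cc2n1` gives 20900 nM, and compound 2 `COc1ccc(C(=O)N(C)c2ccc3[nH]c(-c4n[nH]c5ccccc45)cc3n2)cc1` gives 23700 nM. Compound 3 `CN(c1ccc2[nH]c(-c3n[nH]c4ccccc34)cc2n1)S(=O)(=O)c1ccc(Br)cc1` gives 11500 nM, the lowest of the three numbers: a 1.8-fold lower number from compound 1 to compound 3 (0.26 log units; within the scatter), and a 2.1-fold lower number from compound 2 to compound 3 (0.31 log units; beyond the scatter). Compound 4 `CN(c1ccc2[nH]c(-c3n[nH]c4ccccc34)cc2n1)S(=O)(=O)c1ccc(OC(F)(F)F)cc1` keeps the sulfonyl attachment of compound 3 and changes only the outer ring: trifluoromethoxy in place of bromo on an aromatic carbon, on an aromatic carbon of a six-membered aromatic ring of carbon only. Among the compounds with values here, no measured step swaps one group for another on that ring; the two steps that bear on it exchange the whole attachment and are modest at best. A step no larger than the scatter is therefore expected, a 1.0-fold lower number from compound 3 to compound 4 (0.02 log units; within the scatter). Compound 4 is estimated to give 11000 nM, with a range from 5000 nM to 25000 nM.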

Compound 4, half-maximal inhibitory concentration: 7160 nM
For compound 4 the middle estimate is 1.5-fold (0.19 log units) above the measured one, and the stated range covers the measured number.
By their numbers in this assay, from the lowest: compounds 4, 3, 1 and 2 (each within the scatter of the next, the first and the last beyond it).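

This is the first step shown that changes only the group on the outer ring, para to a large group. With a group of 5 heavy atoms taking the place of a single bromine, the result is a 1.6-fold lower number from compound 3 to compound 4 (0.21 log units; within the scatter), so this position accepts the larger trifluoromethoxy with no change beyond the scatter. Nothing measured here offers an explanation for this step.

Going by these compounds, whether an amine or a carboxylic acid at this place would shift the number beyond the scatter remains open. So does the effect of a longer chain in place of the methyl on the sulfonamide nitrogen.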